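This account rests on a few compounds, and the source may have more. Where it says the series, first, only, none or still open, it means among the compounds named here.

Values in an ADME assay on MT4 cells (Homo sapiens) for cytotoxicity; a higher number here means that more compound is tolerated, a lower number that less compound is tolerated:

Compound 1 `FC(F)(F)c1cccc(NC(=S)Nc2ccccc2)c1`: 39000 nM
Compound 2 `CSCCCNC(=S)Nc1cccc(C(F)(F)F)c1`: 43000 nM
Compound 3 `Fc1ccccc1NC(=S)Nc1cccc(C(F)(F)F)c1`: 47000 nM

Compound 3 stands level with the other two compounds, since the steps that reach it are a 1.2-fold higher number from compound 1 to compound 3 (0.08 log units; within the scatter) and a 1.1-fold higher number from compound 2 to compound 3 (0.04 log units; within the scatter). The next compound, compound 4 `FC(F)(F)c1cccc(NC(=S)NCc2ccco2)c1`, has (furan-2-yl)methyl in place of 2-fluorophenyl on an amide-type nitrogen, whose other neighbour is the thiocarbonyl carbon: (furan-2-yl)methyl in place of 2-fluorophenyl on an amide-type nitrogen. Within the data shown here, no measured compound carries this group, so any expectation rests on earlier exchanges at the same nitrogen. Two such exchanges are known, a 1.1-fold higher number from compound 1 to compound 2 (0.04 log units; within the scatter) and a 1.1-fold higher number from compound 2 to compound 3 (0.04 log units; within the scatter). Among the measured compounds shown here, neither goes beyond the scatter, even though the first replaces an aromatic group with an open chain. On that evidence, no change beyond the scatter is expected in this assay from this exchange either. The estimated step is a 1.1-fold lower number from compound 3 to compound 4 (0.05 log units; within the scatter). Compound 4 is expected at 42000 nM, with an estimated range from 22000 nM to 80000 nM.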

Compound 4, half-maximal cytotoxic concentration: 43000 nM
The estimate for compound 4 lay 1.0-fold (0.01 log units) below the measured number; the range from low to high includes it.
By their numbers in this assay, from the lowest: compounds 1, 2, 4 and 3 (each within the scatter of the next).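

In this assay, compound 4 brings the first hetero atom ring onto this amide-type nitrogen, a five-membered aromatic ring held through a saturated chain carbon, and the exchange for 2-fluorophenyl gives a 1.1-fold lower number from compound 3 to compound 4 (0.04 log units; within the scatter). The result is the same against the other two groups, with a 1.1-fold higher number from compound 1 to compound 4 (0.04 log units; within the scatter) and no change at the digits printed from compound 2 to compound 4 (within the scatter), so aromatic rings of either size and an open chain all stay within the scatter at this nitrogen, and a hydrogen-bond acceptor in the group makes no difference beyond it here. Nothing available explains why this position stays so flat. On these data alone, it remains open whether an amine or a carboxylic acid on this nitrogen would also stay within the scatter. The shared core is also untested, since all four compounds keep it.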